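The source may hold more compounds than are shown below. What is called first, only, known or untested is meant among the compounds shown, and "the series" means these compounds.

Measured in a functional assay on NIH3T3 cells (Mus musculus); a lower number here means that less compound is needed, a higher number that more compound is needed for the effect:
- compound 1 `Cn1cncc1C(OCc1ccc(C#N)cc1-c1ccc(F)c(Cl)c1)c1ccc(C#N)nc1`: 46 nM
- compound 2 `Cn1cncc1C(OCc1nc(N2CCC(O)CC2)c(C#N)cc1-c1cccc(Cl)c1)c1ccc(C#N)cc1`: 3.6 nM
- compound 3 `Cn1cncc1C(OCc1ccc(C#N)nc1-c1ccc2ccccc2c1)c1ccc(C#N)cc1`: 7.4 nM

Compound 1 has the highest number of the three. Compound 3 at 7.4 nM and compound 2 at 3.6 nM both lie lower, beyond the scatter.

Compound 4 `Cn1cncc1C(OCc1ccc(C#N)cc1-c1cc(F)cc(F)c1)c1ccc(C#N)nc1` keeps the core of compound 1 but carries 3,5-difluorophenyl in place of 3-chloro-4-fluorophenyl on an aromatic carbon, ortho to a large group and meta to a cyano group (3,5-difluorophenyl in place of 3-chloro-4-fluorophenyl on an aromatic carbon). Within the data shown here, no measured pair shows this change alone, so the expectation rests on compound 1 at 46 nM. In this assay the expected change is small, none beyond the scatter, with a slight rise estimated as a 1.3-fold higher number from compound 1 to compound 4 (0.12 log units; within the scatter). For compound 4 the estimated value is 60 nM, with an expected range of 20 nM to 180 nM.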

Compound 4, half-maximal effective concentration: 25 nM
For compound 4 the middle estimate is 2.4-fold (0.38 log units) above the measured one, and the stated range covers the measured number.
By their numbers in this assay, from the lowest: compound 2; then compound 3; then compounds 4 and 1 (each within the scatter of the next).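

In this assay, among these compounds, 3,5-difluorophenyl in place of 3-chloro-4-fluorophenyl on an aromatic carbon gives a 1.8-fold lower number from compound 1 to compound 4 (0.26 log units; within the scatter) and is the first direct reading of a change at this position. This exchange of one halogenated phenyl group for another therefore does not separate compound 4 from compound 1. No measurement shown offers an explanation for this result. As far as these compounds go, both groups are halogenated phenyl rings, so it remains open how this position responds to a methoxyphenyl group or to a saturated amine such as morpholine.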